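A few compounds are considered here, and "the series" means these few. Any claim that something is new, unique, unknown or untested is made for them only; others in the source may bear on it.

Measured compounds in a functional assay on thoracic aorta (Rattus norvegicus, strain Wistar), with a stated time of 15 min; a lower number here means that less compound is needed, a higher number that more compound is needed for the effect:
Compound 1 `Cc1ccc(OCc2ccccc2)c(C(C)NC(=O)NS(=O)(=O)c2ccc(Cl)cc2)c1` gives 65300 nM.
Compound 2 `CC(NC(=O)NS(=O)(=O)c1ccc(Cl)cc1)c1ccccc1OCc1ccccc1` gives 157000 nM.
Compound 3 `COc1ccc(Cl)cc1C(C)NC(=O)N(C)S(=O)(=O)c1ccc(C)cc1` gives 13800 nM.

Compound 3 has the lowest number of the three; how its core differs from that of compound 1 is not broken down here, and the two values simply show compound 3 needing less compound than compound 1 and compound 2. Compound 1 and compound 2 differ by hydrogen in place of methyl on an aromatic carbon, a change that gave a 2.4-fold higher number from compound 1 to compound 2 (0.38 log units; beyond the scatter) in this assay.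

Compound 4 `COc1ccc(Cl)cc1C(C)NC(=O)N(C)S(=O)(=O)c1ccccc1` has not yet been measured. It differs from compound 3 by hydrogen in place of methyl on an aromatic carbon. This is the same kind of change as that from compound 1 to compound 2, but the surroundings differ: in compound 1 the methyl sits meta to a large group and para to a benzyloxy group, whereas in compound 3 it sits para to a large group. Resting on the step from compound 1 to compound 2, a rise of similar or somewhat smaller size is expected, a 1.8-fold higher number from compound 3 to compound 4 (0.26 log units; within the scatter), though the different place makes this uncertain. Compound 4 is therefore estimated at 25000 nM in this assay, most likely between 10000 nM and 60000 nM.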

Compound 4, half-maximal effective concentration: 7200 nM
Estimate against measurement, compound 4: 3.5-fold (0.54 log units) above, outside the stated range (below it).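

In this assay, replacing the 4-methylphenyl group by phenyl gave a 1.9-fold lower number from compound 3 to compound 4 (0.28 log units; within the scatter), so the measurement does not separate this pair. Set beside the earlier step, the same replacement of methyl by hydrogen on an aromatic carbon did not carry over unchanged from one core to the other: the same change on two cores in this assay, a 2.4-fold higher number (0.38 log units; beyond the scatter) from compound 1 to compound 2 and a 1.9-fold lower number (0.28 log units; within the scatter) from compound 3 to compound 4, 4.6-fold (0.66 log units) apart, beyond the scatter of two such steps. This shows that the step seen on the core of compound 1 is no reliable guide to the step on the core of compound 3, but with a single pair on each core it does not show which difference between the cores sets the two steps apart.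

The compounds shown leave open whether a different group at this place, such as an amine or a carboxylic acid, would give a step beyond the scatter on the core of compound 3. Equally open, as far as these compounds go, is how the replacement of methyl by hydrogen would read on any further core, with only these two pairs to go on.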